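From isopropyl to prop-1-en-1-yl on a carbonyl carbon

The source may hold more compounds than are shown below. What is called first, only, known or untested is meant among the compounds shown, and "the series" means these compounds.

In a functional assay on MGC-803 cells (Homo sapiens) for inhibition, read by MTT assay, with a stated time of 48 h (on this read-out higher numbers stand for weaker inhibition and lower numbers for stronger inhibition), the two measured compounds give these numbers:
Compound 1 `COCC(=O)N(Cc1ccc(OC)c(O)c1)c1cc(OC)c(OC)c(OC)c1`: 79 nM
Compound 2 `COc1ccc(CN(C(=O)C(C)C)c2cc(OC)c(OC)c(OC)c2)cc1O`: 210 nM

Of these two numbers compound 2 holds the highest. For the measured compounds named here, the single measured step is a 2.7-fold higher number from compound 1 to compound 2 (0.42 log units; beyond the scatter), brought about by isopropyl in place of methoxymethyl on a carbonyl carbon, and it is the only step that bears on what follows, since it touches the same carbonyl carbon. Compound 3 `C/C=C/C(=O)N(Cc1ccc(OC)c(O)c1)c1cc(OC)c(OC)c(OC)c1` differs from compound 2 in one place: prop-1-en-1-yl in place of isopropyl on a carbonyl carbon. Going by the values given here, no measured step exchanges isopropyl for prop-1-en-1-yl, so the data give no direction for this change, and the one step at this carbonyl carbon was itself only modest. In this assay compound 3 is therefore expected to stay close to compound 2, with a 1.3-fold lower number from compound 2 to compound 3 (0.12 log units; within the scatter) expected to remain within the scatter. The estimate for compound 3 is 160 nM, with a range from 60 nM to 430 nM.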

Compound 3, half-maximal inhibitory concentration: 27 nM
Compound 3: middle estimate off by 5.9-fold (0.77 log units), on the high side; the whole stated range lies above it.
By their numbers in this assay, from the lowest: compound 3; then compound 1; then compound 2.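

In this assay, this carbonyl carbon proves sensitive to a change that leaves the heavy-atom count untouched: isopropyl and prop-1-en-1-yl each have 3 heavy atoms, and the entering group differs in carrying one double bond, yet the exchange gives a 7.8-fold lower number from compound 2 to compound 3 (0.89 log units; beyond the scatter). Prop-1-en-1-yl also improves on methoxymethyl at the same place, with a 2.9-fold lower number from compound 1 to compound 3 (0.47 log units; beyond the scatter), so compound 3 is the most potent of the three, its steps to both others lying beyond the scatter. Nothing available explains why this exchange has such an effect.

Whether the double bond itself accounts for the gain remains open, as does what a straight propyl chain would give on this carbonyl carbon. Equally open, going by these compounds, is how an ethenyl group or a longer alkenyl chain would compare with prop-1-en-1-yl there.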